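The source may hold more compounds than are shown below. What is called first, only, known or untested is meant among the compounds shown, and "the series" means these compounds.

Of the compounds shown here, three built on one shared core have so far been measured in an assay on cells for inhibition of interleukin-5 receptor subunit alpha (Mus musculus), read by WST assay, with a stated time of 48 h, in the presence of a further agent that is not named here; a lower number here means a stronger inhibitor, a higher number a weaker inhibitor. Compound 1 `OCCCNCc1nc2c(OCC3CCCCC3)cccc2[nH]1` gives 28500 nM in this assay. Compound 3 `OCCC(NCc1nc2c(OCC3CCCCC3)cccc2[nH]1)c1ccccc1` gives 22000 nM in this assay. Compound 2 `OCCCCCNCc1nc2c(OCC3CCCCC3)cccc2[nH]1` reaches only a limit of the assay, > 30000 nM, and so it stands at the limit of > 30000 nM in this assay, at which 1 of the 3 values shown sits, rather than at a number. The two steps measured between these compounds are small: the change of 2-hydroxyethyl in place of hydroxy on a saturated chain carbon, three bonds along the chain from an amine nitrogen, gave an at least 1.0-fold higher number from compound 1 to compound 2 (0.02 log units; that floor lies within the scatter), and the change of phenyl in place of hydrogen on a saturated chain carbon bound to an amine nitrogen and a saturated chain carbon gave a 1.3-fold lower number from compound 1 to compound 3 (0.11 log units; within the scatter).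

Compound 4 `COc1ccc(CNCc2nc3c(OCC4CCCCC4)cccc3[nH]2)cc1` has not yet been measured. It differs from compound 2 by 4-methoxyphenyl in place of 4-hydroxybutyl on a saturated chain carbon bound to an amine nitrogen. Both measured steps bear on this change, one altering the length of the chain, the other bringing an aromatic ring onto a chain carbon next to the amine, and neither moved the number beyond the scatter. The expected step is therefore an at least 1.2-fold lower number from compound 2 to compound 4 (0.07 log units; that floor lies within the scatter), no movement beyond the scatter in this assay. Compound 4 is expected to give 25000 nM, within a range from 8000 nM to 60000 nM.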

Compound 4, half-maximal inhibitory concentration: > 30000 nM
Compound 4 was reported as a limit (the forecaster's own chance of this, stated with the estimate: 40%); middle value at least 1.2-fold (0.07 log units) away from the limit.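

In this assay compound 4 reaches only a limit, > 30000 nM, so swapping the chain with its terminal hydroxy group for a 4-methoxybenzyl group, which has an aromatic ring and no hydrogen-bond donor, gives no readable gain in strength. Set against compound 1, the only readable result is an at least 1.0-fold higher number from compound 1 to compound 4 (0.02 log units; that floor lies within the scatter), so this floor does not separate the two compounds, while compound 2 and compound 4 both rest on limits and the step between them cannot be read. The new result therefore adds a second kind of group at this place without giving any order among the groups, and the series now gathers at the top of the measurable range: the limit of > 30000 nM in this assay, at which 2 of the 4 values shown sit.

The compounds shown leave open whether the 4-methoxyphenyl group and the 4-hydroxybutyl group truly differ at this place on a saturated chain carbon bound to an amine nitrogen. They also leave open whether a carboxylic acid or a further amine at the end of the chain, in place of the hydroxy group, would give a number clearly lower than those seen so far.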